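Dimethylamino Thiosemicarbazones Against a Gastric Carcinoma Line

The compounds below may be only part of what the source reports. "The series", "measured", "known", "first", "only" and "open" are said of these compounds alone.

Measured compounds:
compound 1 `CN(C)C(=S)N/N=C/c1ccc2cccnc2n1` — 630 nM
compound 2 `NC(=S)N/N=C/c1ccc2cccnc2n1` — > 100000 nM
compound 3 `NC(=S)N/N=C/c1nc2ccccc2s1` — > 100000 nM

In a functional assay on SGC-7901 cells (Homo sapiens) for antiproliferative activity, read by sulforhodamine B assay, with a stated time of 72 h (a higher number here means a weaker inhibitor, a lower number a stronger inhibitor), compound 1 gives 630 nM. Compound 2 reaches only the assay limit, > 100000 nM. Compound 3 likewise reaches only the assay limit, > 100000 nM. Two of the three values sit at that limit (the limit of > 100000 nM in this assay, at which 2 of the 3 values shown sit). The change dimethylamino in place of amino on a thiocarbonyl carbon produced an at least 150-fold lower number from compound 2 to compound 1 (2.20 log units; beyond the scatter). The difference between the core of compound 2 and the core of compound 3 is not broken down here.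

Compound 4 `CN(C)C(=S)N/N=C/c1nc2ccccc2s1` has not yet been measured. It carries the same kind of change on the core of compound 3, (dimethylamino in place of amino on a thiocarbonyl carbon). Because compound 1 shows an at least 150-fold lower number from compound 2 to compound 1 (2.20 log units; beyond the scatter), a step of similar direction from compound 3 to compound 4 in this assay is expected, an at least 50-fold lower number from compound 3 to compound 4 (1.69 log units; beyond the scatter). Compound 4 is therefore estimated at 2000 nM, within 300 nM to 20000 nM.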

Compound 4, half-maximal inhibitory concentration: 830 nM
Compound 4: middle estimate off by 2.4-fold (0.38 log units), on the high side; low and high end bracket the measured number.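

In this assay, dimethylamino in place of amino on a thiocarbonyl carbon again brings a large change, an at least 120-fold lower number from compound 3 to compound 4 (2.08 log units; beyond the scatter), so the change carries from the core of compound 2 to the core of compound 3 in the same direction: the same change on two cores in this assay, an at least 150-fold lower number (2.20 log units; beyond the scatter) from compound 2 to compound 1 and an at least 120-fold lower number (2.08 log units; beyond the scatter) from compound 3 to compound 4; the limit leaves it open whether they differ. Compound 3 gives only a limit of the assay, > 100000 nM. From the compounds shown here alone, the true size of each step stays unknown, and two cores do not show that the change would carry to a further core: the limit of > 100000 nM in this assay, at which 2 of the 4 values shown sit.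

The compounds shown leave open how other amines on the thiocarbonyl carbon, such as methylamino, diethylamino or morpholine, would compare with dimethylamino. They also leave open whether the same step would appear in other cell lines.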